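Removing the pyridin-4-yl group from compound 3

The source may report more compounds than this note shows. Statements on the series, on what has been measured and on what is new or still open speak of the compounds shown alone.

Compound 1 `O=S(=O)(CCC(F)=C(F)F)c1nc2ccc(OC(F)F)cc2[nH]1` — a functional assay on SH-SY5Y cells (Homo sapiens) for cytotoxicity, read by MTT assay, with a stated time of 48 h; on this read-out higher numbers stand for weaker inhibition and lower numbers for stronger inhibition: > 120000 nM (a limit of the assay)
Compound 2 `[O-][S+](CCC(F)=C(F)F)c1nc2ccccc2[nH]1` — this assay: > 120000 nM (a limit of the assay)
Compound 3 `O=S(=O)(CCC(F)=C(F)F)c1ncc(-c2ccncc2)s1` — this assay: > 120000 nM (a limit of the assay)

Among the compounds with values here, all three compounds measured so far sit at the limit of > 120000 nM in this assay, at which 3 of the 3 values shown sit. Compound 3 stands there too: in this assay compound 3 gives only a limit and no number, so it cannot be placed above or below compound 1 or compound 2. Within the data shown here, no step between two measured compounds is reported, so there is no measured change from which to draw.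

Compound 4 `O=S(=O)(CCC(F)=C(F)F)c1nccs1` differs from compound 3 in one place: hydrogen in place of pyridin-4-yl on an aromatic carbon. This shortens the molecule at the five-membered aromatic ring with 1 nitrogen and 1 sulfur while leaving the rest of the shared core untouched.

Since every value seen is a limit, the step from compound 3 to compound 4 is expected to be none beyond the scatter, and compound 4 is most likely to return a limit as well. Compound 4 is therefore estimated at 150000 nM, with a range from 60000 nM to 500000 nM, which corresponds to an expected step that the limit leaves unreadable from compound 3 to compound 4.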

Compound 4, half-maximal inhibitory concentration: > 120000 nM
Compound 4: no number, only a limit (the forecaster's own chance of this, stated with the estimate: 85%); the middle value is on the limit's open side.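

Compound 3 and compound 4 each give only a limit in this assay, so no step can be read between them: the limit of > 120000 nM in this assay, at which 4 of the 4 values shown sit. The compounds shown leave open whether any of them would give a measurable value in this assay, and so whether removing the pyridin-4-yl group changes anything.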